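Kinetic solubility of benzothiazole anilides and a methoxy analogue

The source may hold more compounds than are shown below. What is called first, only, known or untested is meant among the compounds shown, and "the series" means these compounds.

Measured compounds:
- compound 1, `C=CC(=O)Nc1cccc(-c2nc3ccccc3s2)c1`: 180 nM
- compound 2, `O=C(Nc1cccc(-c2nc3ccccc3s2)c1)c1cnccc1Cl`: 320 nM
- compound 3, `O=C(Nc1cccc(-c2nc3ccccc3s2)c1)c1ccc(Cl)nc1Cl`: 350 nM

Three compounds sharing the core of compound 1 were tested in a physicochemical assay for solubility, in phosphate buffer, measured as kinetic solubility, with a stated time of 18 h, at pH 7.4; on this read-out lower numbers stand for lower solubility and higher numbers for higher solubility. Compound 2 stands second highest of the three numbers; its nearest neighbour is compound 3 at a 1.1-fold higher number from compound 2 to compound 3 (0.04 log units; within the scatter), and its furthest is compound 1 at a 1.8-fold higher number from compound 1 to compound 2 (0.25 log units; within the scatter). Compound 3 also differs from compound 1 by a 1.9-fold higher number from compound 1 to compound 3 (0.29 log units; within the scatter). All three measured steps lie within the scatter of the method, so the three values cannot be told apart.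

Compound 4, `COc1ccc(-c2nc3ccccc3s2)cc1NC(=O)c1cnccc1Cl`, has not yet been measured in this assay. Compared with compound 2 the change is methoxy in place of hydrogen on an aromatic carbon. For the measured compounds named here, none of the measured steps involves a substituent on this ring of the shared core, so no step bears directly on the change; the steps that are known all concern the acyl group and all stayed within the scatter. On this basis a step of no size beyond the scatter is expected, and the estimate for compound 4 in this assay is 350 nM with a range of 120 nM to 1000 nM, corresponding to an expected step of a 1.1-fold higher number from compound 2 to compound 4 (0.04 log units; within the scatter).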

Compound 4, solubility: 340 nM
For compound 4 the middle estimate is 1.0-fold (0.01 log units) above the measured one; measured number inside the range.
By their numbers in this assay, from the lowest: compounds 1, 2, 4 and 3 (each within the scatter of the next).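

In this assay, for the compounds shown here, the earlier steps spoke only to the acyl group, and none of them touched the ring of the shared core that carries the anilide nitrogen. Compound 4 extends the picture to that ring: methoxy in place of hydrogen on an aromatic carbon, ortho to a large group and para to a 1,3-benzothiazol-2-yl group, gives a 1.1-fold higher number from compound 2 to compound 4 (0.03 log units; within the scatter), so at this position the change leaves the read-out indistinguishable from that of the parent within the method's scatter. Nothing available bears on why the read-out behaves this way at this position.

Still open is whether a group of another kind on the same carbon, such as an amine, a carboxylic acid or a longer alkoxy chain, would produce a step beyond the scatter, since methoxy is the only replacement for hydrogen shown there. Equally open, on these data alone, is whether methoxy would give the same result alongside the vinyl or 2,6-dichloropyridin-3-yl acyl groups, as its only pairing here is with 4-chloropyridin-3-yl.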